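Propargyl to cyclopropylmethyl on the sulfur of compound 2

A few compounds are considered here, and "the series" means these few. Any claim that something is new, unique, unknown or untested is made for them only; others in the source may bear on it.

Of the compounds shown here, three sharing one core have been tested in a functional assay on HepG2 cells (Homo sapiens) for inhibition, read by MTT assay, with a stated time of 72 h; a lower number here means a stronger inhibitor, a higher number a weaker inhibitor. Compound 1 `C#CCSc1nc(Nc2ccccc2)c2ccncc2n1` gives 29400 nM. Compound 2 `C#CCSc1nc(Nc2cccc(OC)c2)c2ccncc2n1`, bearing a methoxy group on an aromatic carbon, gives 920 nM, and compound 3 `C#CCSc1nc(Nc2cccc(O)c2)c2ccncc2n1`, with a hydroxy group in that place, gives 29500 nM. The steps between them are a 32-fold lower number from compound 1 to compound 2 (1.50 log units; beyond the scatter), a 1.0-fold higher number from compound 1 to compound 3 (0.00 log units; within the scatter) and a 32-fold higher number from compound 2 to compound 3 (1.51 log units; beyond the scatter). Compound 2 thus stands lowest of the three numbers, and both other compounds lie beyond the scatter from it.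

Compound 4 `COc1cccc(Nc2nc(SCC3CC3)nc3cnccc23)c1` differs from compound 2 by cyclopropyl in place of ethynyl on a saturated chain carbon bound to a sulfur. None of the three measured steps touches this sulfur-bound chain: each of them swaps methoxy, hydroxy or hydrogen on an aromatic carbon while the propargylsulfanyl group stays fixed. The measured data therefore give no direct guide to the size or direction of this step, and the most defensible expectation is a change that stays within the scatter, with wide uncertainty on either side.

Compound 4 is accordingly expected to give 1500 nM, with a range from 350 nM to 6500 nM. The expected step of a 1.6-fold higher number from compound 2 to compound 4 (0.21 log units; within the scatter) reflects that absence of relevant precedent rather than any measured trend.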

Compound 4, half-maximal inhibitory concentration: 24900 nM
Estimate against measurement, compound 4: 17-fold (1.22 log units) below, and the stated range ends below it.
By their numbers in this assay, from the lowest: compound 2; then compounds 4, 1 and 3 (each within the scatter of the next).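

In this assay, among the compounds shown here, the change from propargyl to cyclopropylmethyl on the sulfur gives a 27-fold higher number from compound 2 to compound 4 (1.43 log units; beyond the scatter), the first measured step at this position, and a large one. The earlier compounds shown here varied only a group on an aromatic carbon while the propargylsulfanyl group stayed fixed, so they could tie the low number of compound 2 only to its methoxy group; this step shows that the methoxy group alone does not secure that number, and that the group on the sulfur matters just as clearly. Nothing available explains why this exchange of ethynyl for cyclopropyl on a saturated chain carbon bound to a sulfur has so large an effect.

The compounds shown leave open whether the step follows from losing the ethynyl group or from bringing in the three-membered ring, and a plain propyl chain, an allyl group or a longer chain on the sulfur would help to separate the two. They also leave open whether hydroxy or hydrogen in place of methoxy has the same effect when cyclopropylmethyl sits on the sulfur.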